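This account rests on a few compounds, and the source may have more. Where it says the series, first, only, none or still open, it means among the compounds named here.

Measured in a functional assay on the whole organism with Mus musculus as the target, in the maximal electroshock model; a lower number here means that less compound is needed, a higher number that more compound is needed for the effect:
Compound 1 `OC1CCN(c2ccc(-c3ccccc3)nn2)CC1`: 86 mg/kg
Compound 2 `O=[N+]([O-])c1cccc(-c2ccc(N3CCC(O)CC3)nn2)c1`: 79 mg/kg
Compound 3 `OC1CCN(c2ccc(-c3cccc(C(F)(F)F)c3)nn2)CC1`: 63 mg/kg

Compound 1 does not stand apart from the other two in this assay. Its value of 86 mg/kg lies within the scatter of both, and the three compounds cannot be ranked on these numbers. Compound 4 `Cc1ccccc1-c1ccc(N2CCC(O)CC2)nn1` departs from compound 1 by methyl in place of hydrogen on an aromatic carbon, ortho to a large group (methyl in place of hydrogen on an aromatic carbon).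

Two measured steps also replace a hydrogen on an aromatic carbon: a 1.1-fold lower number from compound 1 to compound 2 (0.04 log units; within the scatter) and a 1.4-fold lower number from compound 1 to compound 3 (0.14 log units; within the scatter). Both are small, and neither direction can be told from the scatter. Neither places its group ortho to a large group, however, so they guide the expectation only loosely. No step beyond the scatter is therefore expected in this assay, and no firm direction. The expected step is a 1.1-fold lower number from compound 1 to compound 4 (0.04 log units; within the scatter). The estimate for compound 4 is 78 mg/kg, with an expected range from 42 mg/kg to 145 mg/kg.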

Compound 4, dose for half-maximal effect: 30 mg/kg
For compound 4 the middle estimate is 2.6-fold (0.41 log units) above the measured one; the whole stated range lies above it.
By their numbers in this assay, from the lowest: compound 4; then compounds 3, 2 and 1 (each within the scatter of the next).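

In this assay, a 2.9-fold lower number from compound 1 to compound 4 (0.46 log units; beyond the scatter), and this is the only step from compound 1 shown here that lies beyond the scatter. The two other replacements of a hydrogen on an aromatic carbon, a 1.1-fold lower number from compound 1 to compound 2 (0.04 log units; within the scatter) and a 1.4-fold lower number from compound 1 to compound 3 (0.14 log units; within the scatter), stay within it, and neither places its group ortho to a large group, so methyl at this place shows that a change on this ring can shift the dose needed in this model. Nothing measured here accounts for the step.

The compounds shown leave open whether the place or the methyl itself carries the step. Ethyl or methoxy at the same place, and methyl at the place that nitro holds in compound 2, would separate the two.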